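A Second Change at the Amine Nitrogen of Compound 1

A few compounds are considered here, and "the series" means these few. Any claim that something is new, unique, unknown or untested is made for them only; others in the source may bear on it.

Compound 1 `CCOC(=O)C1=C(NN=C(C(C)=O)C(C)=O)Nc2[nH]nc(C)c2C1c1ccc(N(C)C)cc1` gives 9740 nM in a functional assay on MCF7 cells (Homo sapiens) for inhibition, read by MTT assay, with a stated time of 48 h (a higher number here means a weaker inhibitor, a lower number a stronger inhibitor), the lowest of the two numbers recorded so far. Among the compounds with values here, compound 2 `CCOC(=O)C1=C(N/N=C(/C(=O)Br)c2ccc(Br)cc2)Nc2[nH]nc(C)c2C1c1ccc(N(C)C)cc1` gives 61300 nM in this assay, and the only measured step at this position is a 6.3-fold higher number from compound 1 to compound 2 (0.80 log units; beyond the scatter), a modest weakening.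

Compound 3 `CCOC(=O)C1=C(N/N=C(/C(C)=O)C(=O)OCC)Nc2[nH]nc(C)c2C1c1ccc(N(C)C)cc1` is the next question. Its difference from compound 1 is a group of 10 heavy atoms (6 carbon, 1 nitrogen, 3 oxygen; no ring) in place of a group of 8 heavy atoms (5 carbon, 1 nitrogen, 2 oxygen; no ring), on an amine nitrogen.

Within the data shown here, the one step that bears on this site replaced the group of 8 heavy atoms with a ring-bearing group of 12 heavy atoms and weakened inhibition. The change to compound 3 is smaller: a group of 10 heavy atoms, without a ring, enters in place of the group of 8. A step of that kind is therefore expected to be small and directed toward a higher number, if anywhere, as a 1.3-fold higher number from compound 1 to compound 3 (0.13 log units; within the scatter) describes. Compound 3 is estimated at 13000 nM, with a range from 4500 nM to 40000 nM.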

Compound 3, half-maximal inhibitory concentration: > 100000 nM
Compound 3: a limit, no number (the forecaster's own chance of this, stated with the estimate: 5%); at least 7.6-fold (0.88 log units) between middle value and limit.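

Compound 3 gives no number in this assay, only a limit of the assay: the limit of > 100000 nM in this assay, at which 1 of the 3 values shown sits. Even so, the change from the group of 8 heavy atoms to the group of 10 heavy atoms gives an at least 10-fold higher number from compound 1 to compound 3 (1.01 log units; beyond the scatter), which shows that a large step at this amine nitrogen does not need an entering ring, since neither group here has one. Against the ring-bearing group the reading is an at least 1.6-fold higher number from compound 2 to compound 3 (0.21 log units; that floor lies within the scatter), so these two compounds cannot be put in order.

As far as these compounds go, how far compound 3 lies past its limit remains unknown. The compounds shown also do not tell which part of the entering group carries the step, or how a carboxylic acid or an amide would behave at this amine nitrogen.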